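Chain-terminal azole swap on a shared core

The source may hold more compounds than are shown below. What is called first, only, known or untested is meant among the compounds shown, and "the series" means these compounds.

Measured so far:
compound 1 `Cn1ccnc1S(=O)(=O)CCCSc1nc(-c2ccccc2)c(-c2ccccc2)[nH]1`: 11 nM
compound 2 `Cn1ccnc1SCCCCSc1nc(-c2ccccc2)c(-c2ccccc2)[nH]1`: 38 nM

In an assay for inhibition of sterol O-acyltransferase 1 (Rattus norvegicus) (on this read-out lower numbers stand for stronger inhibition and higher numbers for weaker inhibition), compound 1 gives 11 nM and compound 2 gives 38 nM, so compound 2 stands at the higher of the two numbers. For the measured compounds named here, the single measured step reads a 3.5-fold higher number from compound 1 to compound 2 (0.54 log units; beyond the scatter), a change at a different position of the chain. Compound 3 `c1ccc(-c2nc(SCCCCCCn3cccn3)[nH]c2-c2ccccc2)cc1` carries 2-(1H-pyrazol-1-yl)ethyl in place of (1-methyl-1H-imidazol-2-yl)sulfanyl on a saturated chain carbon, four bonds along the chain from a sulfur. Going by the values given here, no measured step bears on this swap of the terminal azole, so its size cannot be set from the data. Compound 3 is expected to stay near its parent, at about 50 nM (15 nM to 170 nM). The step of a 1.3-fold higher number from compound 2 to compound 3 (0.12 log units; within the scatter) is thus estimated to be small, with a wide range either way.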

Compound 3, half-maximal inhibitory concentration: 48 nM
For compound 3 the middle estimate is 1.0-fold (0.02 log units) above the measured one; the range from low to high includes it.
By their numbers in this assay, from the lowest: compound 1; then compounds 2 and 3 (each within the scatter of the next).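

In this assay, 2-(1H-pyrazol-1-yl)ethyl in place of (1-methyl-1H-imidazol-2-yl)sulfanyl gives a 1.3-fold higher number from compound 2 to compound 3 (0.10 log units; within the scatter), so these two chain-end groups are not told apart at this position. 3-(1H-pyrazol-1-yl)propyl in place of (1-methyl-1H-imidazol-2-yl)sulfonyl gives a 4.4-fold higher number from compound 1 to compound 3 (0.64 log units; beyond the scatter), so compound 1 keeps a lower number than either compound with a sulfonyl-free chain. No evidence on hand accounts for these steps.

From the compounds shown here alone, the azole and the chain sulfur change together in compound 3, and their separate contributions remain open. Also open, going by these compounds, is how an amine or a carboxylic acid at the chain end would read.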